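The source may report more compounds than this note shows. Statements on the series, on what has been measured and on what is new or still open speak of the compounds shown alone.

Measured so far:
compound 1 `CCCCc1oc2ccccc2c1C(=O)c1ccc(OCC(=O)N2CCOCC2)cc1` — > 50000 nM
compound 2 `CCCCc1oc2ccccc2c1C(=O)c1ccc(OCC(=O)Nc2cccc(OC)c2)cc1` — > 50000 nM
compound 3 `CCCCc1oc2ccccc2c1C(=O)c1ccc(OCC(=O)N[C@H](C)c2ccccc2)cc1` — not yet measured

In a functional assay on MDA-MB-231 cells (Homo sapiens) for antiproliferative activity, read by MTT assay, with a stated time of 24 h (on this read-out lower numbers stand for stronger inhibition and higher numbers for weaker inhibition), compound 1 gives > 50000 nM, which is a limit of the assay and not a number. In this assay compound 2 likewise gives > 50000 nM, again a limit. The step that the two limits leave unreadable from compound 1 to compound 2 is therefore not readable. Compound 2 stands at the limit of > 50000 nM in this assay, at which 2 of the 2 values shown sit.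

Compound 3 differs from compound 2 by 1-phenylethyl in place of 3-methoxyphenyl on an amide-type nitrogen. Going by the values given here, no measured step bears on this change, and the single measured step is unreadable, so no direction beyond the scatter can be expected. Compound 3 is estimated at 60000 nM, with a range from 15000 nM to 250000 nM. The expected step is a step that the limit leaves unreadable from compound 2 to compound 3.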

Compound 3, half-maximal inhibitory concentration: 39000 nM
Compound 3: the middle estimate sits 1.5-fold (0.19 log units) above what was measured; measured number inside the range.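

In this assay, the amide-type nitrogen now carries a group that gives a number and not a limit: compound 3, bearing 1-phenylethyl, gives 39000 nM. The steps read an at least 1.2-fold lower number from compound 2 to compound 3 (0.10 log units; that floor lies within the scatter) and an at least 1.2-fold lower number from compound 1 to compound 3 (0.10 log units; that floor lies within the scatter), so neither is shown to pass the scatter. Their true size stays open because the other values are limits: the limit of > 50000 nM in this assay, at which 2 of the 3 values shown sit.

Still open, on these data alone, is whether the opposite configuration of 1-phenylethyl, or benzyl without its methyl, gives a similar number. Also open, as far as these compounds go, is how a carboxylic acid or a longer chain on that nitrogen would read.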